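Dechlorination on the pyridazine: urea series, two pairs

The source may report more compounds than this note shows. Statements on the series, on what has been measured and on what is new or still open speak of the compounds shown alone.

Measured compounds:
compound 1 `O=C(Nc1nc2ccc(F)cc2s1)N1CCN(c2ccc(Cl)nn2)CC1` — > 10000 nM in an assay on HEK293 cells for inhibition of transient receptor potential cation channel subfamily V member 1 (Homo sapiens), read by FLIPR, at pH 5.5 (a lower number here means a stronger inhibitor, a higher number a weaker inhibitor), a limit of the assay
compound 2 `Cc1cc(N2CCN(C(=O)Nc3ccc(C(C)C)cc3)CC2)nnc1Cl` — > 10000 nM in this assay, a limit of the assay
compound 3 `O=C(Nc1nc2ccc(F)cc2s1)N1CCN(c2cccnn2)CC1` — > 10000 nM in this assay, a limit of the assay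

All three measured values sit at the limit of > 10000 nM in this assay, at which 3 of the 3 values shown sit, so none of them is a number. Compound 1 and compound 3 differ by hydrogen in place of chloro on an aromatic carbon; the step from one to the other, a step that the two limits leave unreadable from compound 1 to compound 3, cannot be read because both ends are limits. The difference between the core of compound 1 and the core of compound 2 is not broken down here.

Compound 4 `Cc1cnnc(N2CCN(C(=O)Nc3ccc(C(C)C)cc3)CC2)c1` is not yet measured. Relative to compound 2 it carries hydrogen in place of chloro on an aromatic carbon. This is the same kind of change as that from compound 1 to compound 3, but not the same: in compound 2 the carbon that loses the chloro is, in addition, ortho to a methyl group (1 heavy atom), which the pair of compound 1 and compound 3 lacks.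

What is known rests on compound 2, whose value > 10000 nM is a limit, and on the unreadable step that the two limits leave unreadable from compound 1 to compound 3. From this the step from compound 2 to compound 4 is expected to be a step that the limit leaves unreadable from compound 2 to compound 4, that is, to stay at or near the limit. For compound 4 the estimate in this assay is 15000 nM, with an expected range from 4000 nM to 60000 nM.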

Compound 4, half-maximal inhibitory concentration: 20300 nM
Compound 4: the middle estimate sits 1.4-fold (0.13 log units) below what was measured; the measured number falls inside the stated range.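

In this assay compound 4 gives 20300 nM. For the compounds shown here, compound 2 gives > 10000 nM, a limit of the assay and not a number, and no step from compound 2 to compound 4 can be read. The compounds shown leave open whether hydrogen in place of chloro changes the half-maximal inhibitory concentration in this urea series at all, with or without the methyl group.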